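The source may hold more compounds than are shown below. What is called first, only, known or untested is meant among the compounds shown, and "the series" means these compounds.

Measured so far in a functional assay on HT-29 cells (Homo sapiens) for cytotoxicity, read by MTT assay, with a stated time of 72 h; a higher number here means that more compound is tolerated, a lower number that less compound is tolerated: compound 1 `CSc1ccc(CNc2nc(SC)nc3ncccc23)cc1` with 8750 nM. Compound 2 `COc1ccc(CNc2nc([SeH])nc3ccccc23)cc1` is known only as a limit, and so is compound 3 `CSc1ccc(CNc2nc([SeH])nc3ccccc23)cc1`. In this assay compound 2 stands at the limit > 100000 nM. Compound 3 also stands at the limit > 100000 nM. Between these two the change methoxy in place of methylsulfanyl on an aromatic carbon gave a step that the two limits leave unreadable from compound 3 to compound 2, which cannot be read because both values sit at the limit of > 100000 nM in this assay, at which 2 of the 3 values shown sit. Among the measured compounds shown here, compound 1 is the only compound with a number; how its core differs from the core of compound 3 is not broken down here. Compound 4 `COc1ccc(CNc2nc(SC)nc3ncccc23)cc1` arises from compound 1 by the same change, (methoxy in place of methylsulfanyl on an aromatic carbon). Because the measured step that the two limits leave unreadable from compound 3 to compound 2 gives no readable size, the author expects for compound 4 a step of a 1.0-fold higher number from compound 1 to compound 4 (0.01 log units; within the scatter), within the usual scatter. Compound 4 is accordingly estimated at 9000 nM, between 3000 nM and 30000 nM.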

Compound 4, concentration lethal to 50% of the cells: > 100000 nM
Compound 4 ended at the assay's limit; the forecaster's own chance of this, stated with the estimate: 10%; middle value at least 11-fold (1.04 log units) away from the limit.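

On the core of compound 1, methoxy in place of methylsulfanyl on an aromatic carbon gave an at least 11-fold higher number from compound 1 to compound 4 (1.05 log units; beyond the scatter) in this assay. Compound 4 stands at > 100000 nM, which is a limit and not a number. What the same change does on the core of compound 3 cannot be read, so the results neither confirm nor refute that its effect carries from one core to the other, because compound 2 and compound 3 both sit at the limit: the limit of > 100000 nM in this assay, at which 3 of the 4 values shown sit.

The compounds shown leave open whether another group on that aromatic carbon, such as an amine or a longer chain like ethylsulfanyl, would give a number in this assay. They also leave open how the change would read on a core where both partners give numbers.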